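Chain end swap from compound 3 to compound 4

The source may report more compounds than this note shows. Statements on the series, on what has been measured and on what is new or still open speak of the compounds shown alone.

Values in a functional assay on HeLa cells (Homo sapiens) for cytotoxicity, read by WST assay, with a stated time of 48 h; a higher number here means a weaker inhibitor, a lower number a stronger inhibitor
- compound 1 `COC[C@H](C)[C@H](C)C(c1ccc(O)c(OC)c1)c1ccc(O)c(OC)c1` gives 72000 nM
- compound 2 `COc1cc(C(c2ccc(O)c(OC)c2)[C@H](C)[C@H](C)CO)ccc1O` gives > 100000 nM
- compound 3 `COc1cc(C(c2ccc(O)c(OC)c2)[C@H](CF)C(C)C)ccc1O` gives 19000 nM

The entry for compound 2 is a limit of the assay, not a number. Of the two true numbers, compound 3 holds the lower, with a 3.8-fold lower number from compound 1 to compound 3 (0.58 log units; beyond the scatter) as the gap.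

Compound 4 `COc1cc(C(c2ccc(O)c(OC)c2)[C@H](CC(C)C)C(C)C)ccc1O` differs from compound 3 by isopropyl in place of fluoro on a saturated chain carbon, three bonds along the chain from two aromatic carbons and carries isopropyl in place of fluoro on a saturated chain carbon, three bonds along the chain from two aromatic carbons.

Changes in the same chain gave a 3.8-fold lower number from compound 1 to compound 3 (0.58 log units; beyond the scatter) and an at least 5.2-fold lower number from compound 2 to compound 3 (0.72 log units; beyond the scatter) as steps, the latter resting on a limit. The remaining step, an at least 1.3-fold higher number from compound 1 to compound 2 (0.14 log units; that floor lies within the scatter) as measured, adds little. None of these swaps fluoro for isopropyl, so they only suggest a size. A step in this assay smaller than those into compound 3 is expected, leaning towards a lower number. The expected step is a 1.6-fold lower number from compound 3 to compound 4 (0.20 log units; within the scatter) in this estimate. Compound 4 is estimated at 12000 nM with an expected range from 4000 nM to 40000 nM for the measurement.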

Compound 4, half-maximal inhibitory concentration: 8200 nM
Compound 4: middle estimate off by 1.5-fold (0.17 log units), on the high side, within the range that was stated.
By their numbers in this assay, from the lowest: compound 4; then compound 3; then compound 1. At a limit, above all of these: compound 2.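

In this assay, among these compounds, fluoro is not required at this place on the chain: isopropyl in its stead gives a 2.3-fold lower number from compound 3 to compound 4 (0.36 log units; beyond the scatter), making compound 4 the lowest true number so far. Set against the chains ending in oxygen, the full 1-isopropyl-3-methylbutyl chain gives an 8.8-fold lower number from compound 1 to compound 4 (0.94 log units; beyond the scatter) and an at least 12-fold lower number from compound 2 to compound 4 (1.08 log units; beyond the scatter). Compound 2 is held at a limit of the assay, so its step is only a floor: the limit of > 100000 nM in this assay, at which 1 of the 4 values shown sits.

From the compounds shown here alone, whether a longer chain at this place lowers the number further, or whether the trend stops at isopropyl, stays open. So does the effect of an amine or a carboxylic acid at the same chain end, since a single swap of fluoro for isopropyl cannot separate the size of the group from its other features.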